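This account rests on a few compounds, and the source may have more. Where it says the series, first, only, none or still open, it means among the compounds named here.

Measured in an ADME assay on a cell-free system (plasma, Homo sapiens) for protein binding; a lower number here means a smaller unbound share, a higher number a larger unbound share of the compound:
Compound 1 `Cc1cc2ncccc2cc1Nc1ncc2c(n1)n(C1CCN(C)CC1)c(=O)n2C`: 0.56
Compound 2 `Cc1cc2ncccc2cc1Nc1ncc2c(n1)n(C1CCNCC1)c(=O)n2C`: 0.68

Among the measured compounds shown here, compound 2 stands level with compound 1, the only other measured compound, and the step between them is a 1.2-fold higher number from compound 1 to compound 2 (0.08 log units; within the scatter) and no more. Compound 3 `Cc1cc2ncccc2cc1Nc1ncc2c(n1)n([C@@H]1CCN(C)C1)c(=O)n2C` has yet to be measured. It carries 1-methylpyrrolidin-3-yl in place of piperidin-4-yl on an aromatic nitrogen while the core stays the same. For the measured compounds named here, the one measured step that bears on this change is the swap of hydrogen for methyl on an amine nitrogen in a ring, and it stayed within the scatter. Going by the values given here, no measured compound carries the five-membered ring, so no step beyond the scatter is expected in this assay in either direction. The expected step is a 1.2-fold lower number from compound 2 to compound 3 (0.07 log units; within the scatter) by this estimate. For compound 3 the estimated value is 0.58 with an expected range from 0.38 to 0.82 in this assay.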

Compound 3, unbound fraction: 0.72
For compound 3 the middle estimate is 1.2-fold (0.09 log units) below the measured one; the range from low to high includes it.
By their numbers in this assay, from the lowest: compounds 1, 2 and 3 (each within the scatter of the next).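

Among the compounds shown here, on the aromatic nitrogen of the five-membered aromatic ring, the earlier compounds varied only the group on the ring amine, whereas compound 3 changes the ring itself. In this assay, 1-methylpyrrolidin-3-yl in place of piperidin-4-yl gives (a 1.1-fold higher number from compound 2 to compound 3 (0.02 log units; within the scatter)), and in place of 1-methylpiperidin-4-yl it gives (a 1.3-fold higher number from compound 1 to compound 3 (0.11 log units; within the scatter)), so across these three compounds neither a five-membered ring nor a six-membered one separates the unbound fractions beyond the scatter. Nothing available explains this result.

Going by these compounds, it remains open whether the opposite configuration at the defined stereocentre of 1-methylpyrrolidin-3-yl would read the same. Also open, on these data alone, is whether a different kind of group on this nitrogen, such as an open-chain amine or a carboxylic acid, would produce a step beyond the scatter.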